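This account rests on a few compounds, and the source may have more. Where it says the series, first, only, none or still open, it means among the compounds named here.

`COC(=O)C[C@@H]1C[C@@H](O)[C@H](C)[C@H](c2ccccc2)N1` — compound 1, 8500 nM
`COC(=O)C[C@H]1C[C@@H](O)[C@@H](C)[C@@H](c2ccc(OC)cc2)N1` — compound 2, 23500 nM

Of the compounds shown here, two have been measured in a functional assay on A549 cells (Homo sapiens) for cytotoxicity, read by MTT assay; a higher number here means a weaker inhibitor, a lower number a stronger inhibitor. Compound 1 gives 8500 nM, the lowest of the two numbers; the nearest, compound 2, gives 23500 nM, a higher number beyond the scatter. Compound 3 `COC(=O)C[C@H]1C[C@H](O)[C@H](C)[C@@H](c2ccccc2)N1` has the same atoms and bonds as compound 1 and differs only in configuration: the two compounds have the same atoms and bonds and differ only in configuration as drawn: 3 of 4 stereo elements differ; a stereocentre at a saturated ring carbon is drawn S in compound 1 and R in compound 3; a stereocentre at a saturated ring carbon is drawn R in compound 1 and S in compound 3; a stereocentre at a saturated ring carbon is drawn R in compound 1 and S in compound 3. Within the data shown here, no measured pair shows how such a change in configuration moves the number in this assay. The step of a 1.5-fold higher number from compound 1 to compound 3 (0.18 log units; within the scatter) is expected to be small to moderate toward a higher number. Compound 3 is estimated at 13000 nM, with a range from 4000 nM to 45000 nM.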

Compound 3, half-maximal inhibitory concentration: 69200 nM
The estimate for compound 3 lay 5.3-fold (0.73 log units) below the measured number; the whole stated range lies below it.
By their numbers in this assay, from the lowest: compound 1; then compound 2; then compound 3.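

In this assay, the change of configuration alone gives an 8.1-fold higher number from compound 1 to compound 3 (0.91 log units; beyond the scatter). Among these compounds, this is the first measured pair to show that configuration on the shared core can move the number beyond the scatter. The step can be tied to configuration and to nothing else: the fact that compounds 1 and 3 differ only in the configuration as drawn

Three stereocentres change together, so the compounds shown leave open which of them carries the step, or whether it takes more than one. They also leave open how a core bearing a carboxylic acid or an amide would respond to the same change.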